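Swapping the piperidinyl amine for an oxolanyl ether

The source may report more compounds than this note shows. Statements on the series, on what has been measured and on what is new or still open speak of the compounds shown alone.

Compound 1 `COC(=O)C1=C(CN2CCCCC2)NC(c2nccs2)=NC1(C)c1ccc(F)cc1` heads a set of three analogues that differ only in the group on a saturated chain carbon bound to a double-bonded ring carbon. In an ADME assay on microsomes from liver (Mus musculus) for metabolic stability, read by LC-MS, using NADPH, with stated times of 10 min and 30 min, tested at 1 uM (on this read-out higher numbers stand for fast clearance and lower numbers for slow clearance), compound 1 gives 88 mL/min/kg. Compound 2 `COC(=O)C1=C(CN2CCOCC2=O)NC(c2nccs2)=NC1(C)c1ccc(F)cc1` gives 80 mL/min/kg in this assay, and compound 3 `COC(=O)C1=C(CN2CCC(C(F)(F)F)C2)NC(c2nccs2)=NC1(C)c1ccc(F)cc1` gives 88 mL/min/kg, so compound 1 stands level with compound 3 and within the scatter of compound 2. Compound 4 `COC(=O)C1=C(COC2CCOC2)NC(c2nccs2)=NC1(C)c1ccc(F)cc1` carries a further variation at the same place: (oxolan-3-yl)oxy in place of piperidin-1-yl on a saturated chain carbon bound to a double-bonded ring carbon. The two steps that bear on this change, a 1.1-fold lower number from compound 1 to compound 2 (0.04 log units; within the scatter) and no change at the digits printed from compound 1 to compound 3 (within the scatter), both stayed within the scatter, so no step beyond the scatter is expected here either. For compound 4 the expected clearance is 85 mL/min/kg (range 50 mL/min/kg to 145 mL/min/kg), which means an expected step of a 1.0-fold lower number from compound 1 to compound 4 (0.02 log units; within the scatter).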

Compound 4, clearance: 79 mL/min/kg
Compound 4: the middle estimate sits 1.1-fold (0.03 log units) above what was measured; the measured number falls inside the stated range.
By their numbers in this assay, from the lowest: compounds 4, 2, 1 and 3 (each within the scatter of the next).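

Each earlier group was joined to the chain carbon through a ring nitrogen, whereas (oxolan-3-yl)oxy is joined through oxygen, and in this assay this change still stays within the scatter (a 1.1-fold lower number from compound 1 to compound 4 (0.05 log units; within the scatter)). The same holds against the other two groups (a 1.1-fold lower number from compound 3 to compound 4 (0.05 log units; within the scatter)) and (a 1.0-fold lower number from compound 2 to compound 4 (0.01 log units; within the scatter)). Nothing available explains this lack of separation.

As far as these compounds go, it remains open whether a carboxylic acid, a primary amine or a longer chain at this place would move the number beyond the scatter.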